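The source may report more compounds than this note shows. Statements on the series, on what has been measured and on what is new or still open speak of the compounds shown alone.

Of the compounds shown here, three sharing one core have been tested in an ADME assay on HepG2 cells (Homo sapiens) for cytotoxicity, read by luminescence, CellTiter-Glo and ATP content, with a stated time of 72 h; on this read-out higher numbers stand for an effect only at larger amounts of compound and lower numbers for an effect already at smaller amounts. Compound 1 `COc1ccc(F)cc1CNCCCNc1ccnc2cc(CC(C)C)ccc12` gives 2900 nM. Compound 2 `COc1ccc(F)cc1CNCCCNc1ccnc2cc(Cc3ccccc3)ccc12` gives 7990 nM, and compound 3 `COc1ccc(-c2ccc3c(NCCCNCc4cc(F)ccc4OC)ccnc3c2)cc1` gives 5960 nM. There is a 2.8-fold higher number from compound 1 to compound 2 (0.44 log units; beyond the scatter), with phenyl in place of isopropyl on a saturated chain carbon bound to an aromatic carbon. There is also a 2.1-fold higher number from compound 1 to compound 3 (0.31 log units; beyond the scatter), with 4-methoxyphenyl in place of isobutyl on an aromatic carbon, while a 1.3-fold lower number from compound 2 to compound 3 (0.13 log units; within the scatter) remains within the scatter. Compound 3 thus holds the second highest of the three numbers, close to compound 2 and separated from compound 1.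

Compound 4 `COc1ccc(F)cc1CNCCCNc1ccnc2cc(Oc3ccccc3)ccc12` has not yet been measured. Against compound 3 the change is phenoxy in place of 4-methoxyphenyl on an aromatic carbon. Going by the values given here, the steps that bear on it are those varying the group on an aromatic carbon of the core: a 2.1-fold higher number from compound 1 to compound 3 (0.31 log units; beyond the scatter) and a 1.3-fold lower number from compound 2 to compound 3 (0.13 log units; within the scatter), both small, and a 2.8-fold higher number from compound 1 to compound 2 (0.44 log units; beyond the scatter), also modest. Phenoxy, like 4-methoxyphenyl and benzyl, brings one six-membered aromatic ring of carbon only and one hydrogen-bond acceptor. A step no larger than the scatter is therefore expected, a 1.0-fold higher number from compound 3 to compound 4 (0.00 log units; within the scatter). Compound 4 is estimated at 6000 nM, within a range from 2500 nM to 14000 nM.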

Compound 4, half-maximal effective concentration: 1500 nM
Estimate against measurement, compound 4: 4.0-fold (0.60 log units) above, outside the stated range (below it).
By their numbers in this assay, from the lowest: compounds 4 and 1 (each within the scatter of the next); then compounds 3 and 2 (each within the scatter of the next).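

In this assay, going by these compounds alone, the group on this aromatic carbon matters more than the earlier compounds suggested: phenoxy in place of 4-methoxyphenyl gives a 4.0-fold lower number from compound 3 to compound 4 (0.60 log units; beyond the scatter), and phenoxy in place of benzyl gives a 5.3-fold lower number from compound 2 to compound 4 (0.73 log units; beyond the scatter), even though phenoxy and 4-methoxyphenyl have the same counts of aromatic rings, hydrogen-bond donors and hydrogen-bond acceptors. Carrying an aromatic ring at this position therefore does not by itself go with a higher number: compound 2 and compound 3 fit that idea, but compound 4 goes against it, since phenoxy in place of isobutyl gives a 1.9-fold lower number from compound 1 to compound 4 (0.29 log units; within the scatter), a step within the scatter. No measurement here explains why these groups differ in this way.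

Phenoxy differs from 4-methoxyphenyl both in having an oxygen link to the core and in lacking the ring's methoxy group, so the compounds shown cannot say which of the two features goes with the lower number. A 4-methoxyphenoxy group would help separate them, while an anilino group or a phenylthio group would show whether the oxygen link itself matters.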